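The compounds below may be only part of what the source reports. "The series", "measured", "known", "first", "only" and "open" are said of these compounds alone.

Going by the values given here, compound 3 `CCOc1ncc(-c2nc(C(F)(F)F)sc2N2CCN(C(=O)Cn3cnc(C(F)(F)F)n3)[C@H](C)C2)cn1` gives 524 nM in an assay on blood for inhibition of C-X-C chemokine receptor type 3 (Homo sapiens), with a stated time of 30 min (on this read-out higher numbers stand for weaker inhibition and lower numbers for stronger inhibition), the highest of the three numbers measured so far: compound 1 `CCOc1ncc(-c2nc(C(F)(F)F)sc2N2CCN(C(=O)Cn3ccc4cnccc43)[C@H](C)C2)cn1` gives 25 nM and compound 2 `CCOc1ncc(-c2nc(C(F)(F)F)sc2N2CCN(C(=O)Cn3nc(C)cc3C)[C@H](C)C2)cn1` gives 60 nM. Compound 4 `CCOc1ncc(-c2nc(C(F)(F)F)sc2N2CCN(C(=O)Cn3cc(Cl)cn3)[C@H](C)C2)cn1` differs from compound 3 by 4-chloro-1H-pyrazol-1-yl in place of 3-(trifluoromethyl)-1H-1,2,4-triazol-1-yl on a saturated chain carbon bound to a carbonyl carbon. The step that bears most directly on this change is an 8.7-fold higher number from compound 2 to compound 3 (0.94 log units; beyond the scatter), where a 3,5-dimethyl-1H-pyrazol-1-yl gave way to the triazole now leaving; a 21-fold higher number from compound 1 to compound 3 (1.32 log units; beyond the scatter) points the same way, and a 2.4-fold higher number from compound 1 to compound 2 (0.38 log units; beyond the scatter) was smaller. Compound 4 returns to a five-membered aromatic ring with 2 hetero atoms, as in compound 2, so a large part of that step is expected to come back, giving a 4.4-fold lower number from compound 3 to compound 4 (0.64 log units; beyond the scatter). The number for compound 4 is therefore estimated at 120 nM, with a range from 40 nM to 360 nM.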

Compound 4, half-maximal inhibitory concentration: 245 nM
Beside the measured number, compound 4's estimate is 2.0-fold (0.31 log units) below it, within the range that was stated.
By their numbers in this assay, from the lowest: compound 1; then compound 2; then compound 4; then compound 3.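

In this assay, 4-chloro-1H-pyrazol-1-yl in place of the triazole recovers little (a 2.1-fold lower number from compound 3 to compound 4 (0.33 log units; beyond the scatter)). A five-membered aromatic ring with 2 hetero atoms is thus not enough at this saturated chain carbon, as 3,5-dimethyl-1H-pyrazol-1-yl stays ahead (a 4.1-fold higher number from compound 2 to compound 4 (0.61 log units; beyond the scatter)). The group of compound 1 keeps a wider lead (a 9.8-fold higher number from compound 1 to compound 4 (0.99 log units; beyond the scatter)). Open is how a pyrazole carrying a single methyl group or an amine at this place would compare with compound 2, and no measurement shown accounts for these steps.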